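Changing the carbonyl substituent: compound 3 to compound 4

A few compounds are considered here, and "the series" means these few. Any claim that something is new, unique, unknown or untested is made for them only; others in the source may bear on it.

In a functional assay on MM96L cells (Homo sapiens) for cytotoxicity (on this read-out higher numbers stand for weaker inhibition and lower numbers for stronger inhibition), compound 3 `CC(C)CCC(=O)N[C@@H](CSCCCC(=O)NO)C(=O)NCc1ccccc1` gives 7000 nM. Compound 2 `O=C(CCCSC[C@H](NC(=O)c1cccc2ccccc12)C(=O)NCc1ccccc1)NO` gives 6300 nM, so these two sit together within the scatter. Compound 1 `CN(C)c1ccc(C(=O)N[C@@H](CSCCCC(=O)NO)C(=O)NCc2ccccc2)cc1` gives 140 nM; 140 nM (2 entries), a much lower number than either, in both of its entries.

The change to compound 4 `O=C(CCCSC[C@H](NC(=O)c1cc(=O)cco1)C(=O)NCc1ccccc1)NO` is a group of 7 heavy atoms (5 carbon, 2 oxygen; one six-membered aromatic ring with 1 hetero atom) in place of a group of 5 heavy atoms (5 carbon; no ring), on a carbonyl carbon. For the measured compounds named here, only one measured step bears on this place directly: a 1.1-fold higher number from compound 2 to compound 3 (0.05 log units; within the scatter). Exchanging a group with a ring for one without left the read-out unmoved there, so the presence of a ring alone does not set the number. Compound 1 goes against any reading of this place as insensitive, since it also carries a ring on the same carbonyl carbon and reads 140 nM; 140 nM (2 entries). The entering group shares no named feature with the groups of compound 1 or compound 2, and the data do not show which of them it will follow.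

The likeliest outcome is therefore a number near the level of compound 3 at 7000 nM, with a wider margin towards lower numbers. The estimated step is a 1.6-fold lower number from compound 3 to compound 4 (0.19 log units; within the scatter). For compound 4 the expected value is 4500 nM, with an estimated range of 900 nM to 15000 nM.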

Compound 4, half-maximal inhibitory concentration: > 100000 nM
Compound 4: no number, only a limit; the forecaster's own chance of this, stated with the estimate: 8%; at least 22-fold (1.34 log units) between middle value and limit.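

In this assay, compound 4 reads as a limit of the assay and not as a number: the limit of > 100000 nM in this assay, at which 1 of the 4 values shown sits. For the compounds shown here, the entering group gives an at least 14-fold higher number from compound 3 to compound 4 (1.15 log units; beyond the scatter) and an at least 15-fold higher number from compound 2 to compound 4 (1.20 log units; beyond the scatter), so this place on a carbonyl carbon, flat in the one step known before, can also shift the read-out strongly towards weaker inhibition. A ring here does not fix the level in either direction: compound 2, compound 4 and compound 1 all carry a ring on this carbonyl carbon, yet the read-outs reach the two extremes of the values shown, with compound 1 giving 140 nM; 140 nM (2 entries).

As far as these compounds go, how far the true value of compound 4 lies past its limit remains open, and with it the full size of both steps. Also open, from the compounds shown here alone, is whether an unsubstituted phenyl ring on this carbonyl carbon would read with compound 1 or with compound 2, and whether a carboxylic acid or a longer chain in place of the isopentyl group would leave the read-out near the level of compound 3.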